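A few compounds are considered here, and "the series" means these few. Any claim that something is new, unique, unknown or untested is made for them only; others in the source may bear on it.

Of the compounds shown here, two of this set have been measured. Compound 1 `CC(C)CNC(=O)n1cc(-c2ccccc2)oc1=O` carries an isobutyl group on the carbamoyl nitrogen and a plain phenyl ring on the shared core; in an assay on isolated protein for inhibition of acid ceramidase (Homo sapiens), read by LC-MS, with a stated time of 1 h (on this read-out higher numbers stand for weaker inhibition and lower numbers for stronger inhibition), compound 1 gives 1700 nM. Compound 2 `COc1ccccc1-c1cn(C(=O)NCCCCc2ccccc2)c(=O)o1` differs in more than one place, with a 4-phenylbutyl chain on the carbamoyl nitrogen and a 2-methoxyphenyl group on the core; in this assay compound 2 gives 177 nM. Of the two numbers compound 2 has the lower one, and the gap to compound 1 is beyond the scatter, so compound 2 stands as the stronger inhibitor of the pair.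

Compound 3 `O=C(NCCCCc1ccccc1)n1cc(-c2cscn2)oc1=O` keeps the 4-phenylbutyl chain and changes only the group on the core: 1,3-thiazol-4-yl in place of 2-methoxyphenyl on an aromatic carbon. Among the compounds with values here, no measured pair shows this exchange, so its effect is unknown here. Because compound 2 gives 177 nM with the larger six-membered group, and the incoming ring is smaller with a different pattern of acceptors, a moderate weakening is expected, as a 2.5-fold higher number from compound 2 to compound 3 (0.41 log units; beyond the scatter). Compound 3 is therefore estimated at 450 nM, within a range from 120 nM to 1700 nM.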

Compound 3, half-maximal inhibitory concentration: 44 nM
Beside the measured number, compound 3's estimate is 10-fold (1.01 log units) above it; the whole stated range lies above it.
By their numbers in this assay, from the lowest: compound 3; then compound 2; then compound 1.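

The core position next to the ring oxygen turns out to be sensitive to the group it carries, and a large six-membered carbon ring is not needed there. With the 4-phenylbutyl chain held fixed, putting 1,3-thiazol-4-yl in place of 2-methoxyphenyl gives a 4.0-fold lower number from compound 2 to compound 3 (0.60 log units; beyond the scatter) in this assay, a modest gain that lies beyond the usual scatter. Within the data shown here, this is the first change in the set made in one place only, since the two earlier compounds differ in both the chain and the core group, so it is also the first effect that can be assigned to a single group, though nothing presented here explains the gain.

This one exchange alters ring size and hetero atoms together, so the two cannot yet be told apart, and a plain phenyl ring, a pyridine ring or a thiophene ring at this place on the 4-phenylbutyl compound would be needed to separate them. Also open, going by these compounds, is whether 1,3-thiazol-4-yl would bring a similar gain with the isobutyl group of compound 1, and what the chain alone contributes.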